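Chloro to fluoro on a weak growth inhibitor

The compounds below may be only part of what the source reports. "The series", "measured", "known", "first", "only" and "open" are said of these compounds alone.

Compound 1 `O=C(/C=C/c1ccc(Cl)cc1)c1ccccc1`: 16500 nM
Compound 2 `Cc1ccc(COc2ccc(C(=O)/C=C/c3ccc(F)cc3)cc2)cc1`: > 50000 nM, a limit and not a number

For the measured compounds named here, in a functional assay on HCT-116 cells (Homo sapiens) for inhibition, read by sulforhodamine B assay, with a stated time of 3 days (a lower number here means a stronger inhibitor of growth, a higher number a weaker inhibitor of growth), compound 1 gives 16500 nM, the only true number so far. For compound 2, this assay reports only a limit: > 50000 nM.

Compound 3 `O=C(/C=C/c1ccc(F)cc1)c1ccccc1` changes compound 1 in one place: fluoro in place of chloro on an aromatic carbon. Going by the values given here, no measured pair shows this exchange, so the expectation rests on compound 1 alone, at 16500 nM. A change within the usual scatter is expected, leaning slightly towards weaker inhibition. The expected step is a 1.3-fold higher number from compound 1 to compound 3 (0.12 log units; within the scatter). For compound 3 the estimate is 22000 nM, with an expected range from 9000 nM to 50000 nM.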

Compound 3, concentration for 50% growth inhibition: 4360 nM
Beside the measured number, compound 3's estimate is 5.0-fold (0.70 log units) above it; the measured number lies below the stated range.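

In this assay, the exchange gives a 3.8-fold lower number from compound 1 to compound 3 (0.58 log units; beyond the scatter). A single halogen on this aromatic carbon, para to a large group, therefore affects growth inhibition measurably, and here fluoro gives the stronger compound, though the step is modest. Nothing shown here explains why the step runs in this direction. Going by these compounds, it remains open how bromo, a methoxy group or an amine would behave at this position. Also open, on these data alone, is whether the chloro-to-fluoro exchange would give a similar step on a different core.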